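This account rests on a few compounds, and the source may have more. Where it says the series, first, only, none or still open, it means among the compounds named here.

In a functional assay on A549 cells (Homo sapiens) for antiproliferative activity, read by MTT assay, with a stated time of 72 h (a higher number here means a weaker inhibitor, a lower number a stronger inhibitor), compound 1 `CCOc1ccc(-c2ccc3ncn(-c4cc(OC)c(OC)c(OC)c4)c3c2)cc1` gives 8550 nM, compound 2 `COc1ccc(-c2ccc3ncn(-c4cc(OC)c(OC)c(OC)c4)c3c2)cc1F` gives 1430 nM and compound 3 `COc1cc(-n2cnc3ccc(-c4ccc([N+](=O)[O-])cc4)cc32)cc(OC)c1OC` gives 8940 nM. Compound 3 thus sits level with compound 1, and both lie well above compound 2. Compound 4 `COc1cc(-n2cnc3ccc(-c4ccc(C(F)(F)F)cc4)cc32)cc(OC)c1OC` alters compound 3 at one place: trifluoromethyl in place of nitro on an aromatic carbon, para to a large group. Within the data shown here, no measured step involves trifluoromethyl. The nearest guide is a 1.0-fold higher number from compound 1 to compound 3 (0.02 log units; within the scatter), a swap at the same place. The larger steps, a 6.0-fold lower number from compound 1 to compound 2 (0.78 log units; beyond the scatter) and a 6.3-fold higher number from compound 2 to compound 3 (0.80 log units; beyond the scatter), both involve the 3-fluoro-4-methoxyphenyl group, which compound 4 lacks. The expected change is therefore small, and a 1.4-fold lower number from compound 3 to compound 4 (0.14 log units; within the scatter) is estimated, with no clear direction. For compound 4, the estimated value is 6500 nM, within a range of 2200 nM to 19000 nM.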

Compound 4, half-maximal inhibitory concentration: 3390 nM
Beside the measured number, compound 4's estimate is 1.9-fold (0.28 log units) above it, and the stated range covers the measured number.
By their numbers in this assay, from the lowest: compound 2; then compound 4; then compounds 1 and 3 (each within the scatter of the next).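

Trifluoromethyl is the first group at this place on the aromatic ring to separate clearly from nitro in this assay (a 2.6-fold lower number from compound 3 to compound 4 (0.42 log units; beyond the scatter)), so the place is not indifferent to its substituent, as the level nitro and ethoxy compounds had suggested. Trifluoromethyl also improves on ethoxy (a 2.5-fold lower number from compound 1 to compound 4 (0.40 log units; beyond the scatter)), but the 4-(trifluoromethyl)phenyl group still falls short of 3-fluoro-4-methoxyphenyl (a 2.4-fold higher number from compound 2 to compound 4 (0.37 log units; beyond the scatter)). Nothing available explains these differences. As far as these compounds go, whether an amine, a carboxylic acid or a longer chain here would give a lower or higher number remains open.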